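Removing the Methoxy: Expected Cytotoxicity of Compound 4

A few compounds are considered here, and "the series" means these few. Any claim that something is new, unique, unknown or untested is made for them only; others in the source may bear on it.

Measured compounds:
compound 1, `CCOC(=O)c1c(-c2ccc(F)cc2)oc2ccc(OCCCN3C(=O)C(=O)c4cc(F)ccc43)cc12`, gives 512000 nM
compound 2, `CCOC(=O)c1c(-c2ccccc2)oc2ccc(OCCCN3C(=O)C(=O)c4cc(OC)ccc43)cc12`, gives 256000 nM
compound 3, `CCOC(=O)c1c(-c2ccc(F)cc2)oc2ccc(OCCCN3C(=O)C(=O)c4cc(OC)ccc43)cc12`, gives 128000 nM

These three numbers come from an ADME assay on Vero cells (Chlorocebus sabaeus) for cytotoxicity, read by MTT assay, with a stated time of 72 h; on this read-out higher numbers stand for lower toxicity in this test and lower numbers for higher toxicity in this test. Compound 3 sits at the low end of the three, but only its gap to compound 1 is firm: a 4.0-fold lower number from compound 1 to compound 3 (0.60 log units; beyond the scatter), beyond the scatter, whereas a 2.0-fold lower number from compound 2 to compound 3 (0.30 log units; within the scatter) lies within the scatter, so compound 2 and compound 3 cannot be told apart on this assay.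

Compound 4, `CCOC(=O)c1c(-c2ccc(F)cc2)oc2ccc(OCCCN3C(=O)C(=O)c4ccccc43)cc12`, differs from compound 3 by hydrogen in place of methoxy on an aromatic carbon. For the measured compounds named here, no measured pair shows this exact change. Going by the values given here, the step that bears on it most is the one from compound 1 to compound 3, where methoxy entering in place of fluoro lowered the number beyond the scatter; the step from compound 2 to compound 3 concerns a different ring and stays within the scatter. Taking methoxy away is therefore expected to move the number back upward by a modest amount, a 2.0-fold higher number from compound 3 to compound 4 (0.30 log units; within the scatter). Compound 4 is expected to give about 256000 nM, within a range from 100000 nM to 600000 nM.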

Compound 4, half-maximal cytotoxic concentration: 256000 nM
For compound 4 middle estimate and measured number coincide at the digits printed, and the stated range covers the measured number.
By their numbers in this assay, from the lowest: compounds 3, 2, 4 and 1 (each within the scatter of the next, the first and the last beyond it).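

In this assay, this position now carries three groups on the same core: hydrogen in place of methoxy gives a 2.0-fold higher number from compound 3 to compound 4 (0.30 log units; within the scatter), and hydrogen in place of fluoro gives a 2.0-fold lower number from compound 1 to compound 4 (0.30 log units; within the scatter). Neither step leaves the scatter, so hydrogen cannot be told apart from either group, and only methoxy and fluoro, the two ends of the series, stand apart on this aromatic carbon. Compound 4 also gives a second reading of fluoro in place of hydrogen, and the two readings point in opposite directions: the same change on two cores in this assay, a 2.0-fold lower number (0.30 log units; within the scatter) from compound 2 to compound 3 and a 2.0-fold higher number (0.30 log units; within the scatter) from compound 4 to compound 1, 4.0-fold (0.60 log units) apart, beyond the scatter of two such steps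

On these data alone, whether an amine or a carboxylic acid at this position would move the number beyond the scatter from hydrogen remains open. The compounds shown also do not tell why the two fluoro readings differ.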